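Losing one amide methyl from compound 1

This account rests on a few compounds, and the source may have more. Where it says the series, first, only, none or still open, it means among the compounds named here.

In an ADME assay on Caco-2 cells (Homo sapiens) for permeability, in the apical to basolateral direction (a higher number here means that the compound crosses the layer faster, a lower number that the compound crosses the layer more slowly), compound 1 (`COC(=O)N1CCN([C@H]2CC[C@H](Nc3ncnn4ccc([C@H](C)CC(=O)N(C)C)c34)CC2)CC1`) gives 18 10^-6 cm/s and is the only one of the three measured compounds to return a number. Compound 2 (`CC(=O)N1CCN([C@H]2CC[C@H](Nc3ncnn4ccc([C@H]5CC[C@H](C(N)=O)CC5)c34)CC2)CC1`) gives < 0.7 10^-6 cm/s as a limit of the assay and not a number. Compound 3 (`CN(C)[C@H]1CC[C@H](Oc2ncnn3ccc([C@H]4CC[C@H](C(N)=O)CC4)c23)CC1`) gives < 2 10^-6 cm/s and this too is a limit.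

Compound 4 (`CNC(=O)C[C@@H](C)c1ccn2ncnc(N[C@H]3CC[C@H](N4CCN(C(=O)OC)CC4)CC3)c12`) departs from compound 1 at a single place (hydrogen in place of methyl on an amide-type nitrogen): hydrogen in place of methyl on an amide-type nitrogen, which turns dimethylcarbamoyl into methylcarbamoyl. Going by the values given here, no measured pair shows this change on its own, so the size of the step in this assay has to be judged. Compound 2 and compound 3 also lack the methyl groups on their amide nitrogen and gave only limits, but they differ from compound 1 elsewhere as well, so they offer no more than a weak hint of direction. Starting from compound 1 at 18 10^-6 cm/s in this assay a moderate fall is expected, somewhat beyond the scatter, that still leaves a measurable number. The estimated step is a 2.6-fold lower number from compound 1 to compound 4 (0.41 log units; beyond the scatter) on this reasoning. Compound 4 is estimated at 7 10^-6 cm/s with an expected range of 2.5 10^-6 cm/s to 16 10^-6 cm/s when it is measured.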

Compound 4, apparent permeability: 22 10^-6 cm/s
Estimate against measurement, compound 4: 3.1-fold (0.50 log units) below; measured number outside the range, above it.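

In this assay, going by these compounds alone, replacing one methyl with hydrogen on the amide-type nitrogen, which turns dimethylcarbamoyl into methylcarbamoyl, gives a 1.2-fold higher number from compound 1 to compound 4 (0.09 log units; within the scatter), so this pair, unlike the earlier compounds, isolates the change and the two compounds cannot be told apart in this read-out. The weak hint from compound 2 and compound 3, which also lack methyl groups on their amide nitrogen but differ from compound 1 elsewhere as well, is not borne out by this single change at this position. Compound 2 remains a limit of the assay and not a number: the limit of < 0.7 10^-6 cm/s in this assay, at which 1 of the 4 values shown sits.

As far as these compounds go, compound 3 is also a limit of the assay and not a number, and which of their other differences from compound 4 goes with these limits stays open: the limit of < 2 10^-6 cm/s in this assay, at which 1 of the 4 values shown sits. Within the data shown here, also open is how the read-out would respond if this side chain ended in a carboxamide with no methyl on its nitrogen, a carboxylic acid or an amine, or if a longer chain carried the methylcarbamoyl group, since this one pair speaks only for the single step from dimethylcarbamoyl to methylcarbamoyl.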